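Urea aryl change from compound 2 to compound 3

The compounds below may be only part of what the source reports. "The series", "measured", "known", "first", "only" and "open" are said of these compounds alone.

Of the compounds shown here, two so far share one core and differ only in the group on the amide-type nitrogen. In a functional assay on CCRF-CEM cells (Homo sapiens) for inhibition, read by sulforhodamine B assay, with a stated time of 48 h (on this read-out lower numbers stand for stronger inhibition of growth and higher numbers for weaker inhibition of growth), compound 1 `COc1cc(-c2nn(-c3cccc(NC(=O)Nc4cc(C(F)(F)F)cc(C(F)(F)F)c4)c3)cc2-c2ccncc2)ccc1Cl` gives 498 nM, and compound 2 `COc1cc(-c2nn(-c3cccc(NC(=O)Nc4ccc(Cl)c(Cl)c4)c3)cc2-c2ccncc2)ccc1Cl` gives 1040 nM. Compound 2 thus holds the higher of the two numbers, with compound 1 lying beyond the scatter below it. Compound 3 `COc1cc(-c2nn(-c3cccc(NC(=O)Nc4cccc(C(F)(F)F)c4)c3)cc2-c2ccncc2)ccc1Cl` carries 3-(trifluoromethyl)phenyl in place of 3,4-dichlorophenyl on an amide-type nitrogen, a single trifluoromethyl where compound 1 carries two. Among the measured compounds shown here, no measured step matches this change; the expected step is a 1.5-fold lower number from compound 2 to compound 3 (0.17 log units; within the scatter), a modest move downward, within or just beyond the scatter. Compound 3 is therefore estimated at 700 nM, with a range of 350 nM to 1400 nM in this assay.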

Compound 3, concentration for 50% growth inhibition: 945 nM
Compound 3: middle estimate off by 1.4-fold (0.13 log units), on the low side; measured number inside the range.
By their numbers in this assay, from the lowest: compounds 1, 3 and 2 (each within the scatter of the next, the first and the last beyond it).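

In this assay, 3-(trifluoromethyl)phenyl in place of 3,4-dichlorophenyl on an amide-type nitrogen gives a 1.1-fold lower number from compound 2 to compound 3 (0.04 log units; within the scatter), so this position does not tell these two groups apart. Hydrogen in place of trifluoromethyl on an aromatic carbon gives a 1.9-fold higher number from compound 1 to compound 3 (0.28 log units; within the scatter), so that single change also stays inside the scatter, although compound 1 and compound 2 lie beyond it. Compound 3 therefore does not resolve the gap between them.

Nothing available here gives a reason for these numbers. Going by these compounds, whether a methoxy, a nitrile or an amine on this aryl group would move the number beyond the scatter remains open.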